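A few compounds are considered here, and "the series" means these few. Any claim that something is new, unique, unknown or untested is made for them only; others in the source may bear on it.

Compound 1 `CCCCc1cn(-c2ccc(NC(=O)Nc3cc(CCC(C)=O)ccc3C)cc2)nn1` is one of three compounds tested in an assay on isolated protein for inhibition of ATP-dependent RNA helicase DDX3X (Homo sapiens), read by FRET, with stated times of 30 s and 40 min (a lower number here means a stronger inhibitor, a higher number a weaker inhibitor), where compound 1 gives 2490 nM. Compound 2 `Cc1ccccc1NC(=O)Nc1ccc(-n2cc(CCCN(C)C)nn2)cc1` gives 2900 nM in this assay, a value within the scatter of compound 1, so the two cannot be told apart. Compound 3 `O=C(Nc1ccc(-n2cc(CCO)nn2)cc1)Nc1ccccc1C(F)(F)F` gives 11200 nM, a higher number that lies beyond the scatter, so compound 3 is the weaker of that pair. Compound 4 `CCCCc1cn(-c2ccc(NC(=O)Nc3cc(O)ccc3C)cc2)nn1` has not been measured; it differs from compound 1 by hydroxy in place of 2-acetylethyl on an aromatic carbon. Among the compounds with values here, no single-change step between measured compounds is known, so the effect of this change has to be guessed. A small loss is expected, with the step of a 1.6-fold higher number from compound 1 to compound 4 (0.21 log units; within the scatter) possibly staying within the scatter. For compound 4 the estimate in this assay is 4000 nM, within 1500 nM to 12000 nM.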

Compound 4, half-maximal inhibitory concentration: 490 nM
Beside the measured number, compound 4's estimate is 8.2-fold (0.91 log units) above it; measured number below the stated range.
By their numbers in this assay, from the lowest: compound 4; then compounds 1 and 2 (each within the scatter of the next); then compound 3.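

Within the data shown here, replacing 2-acetylethyl with hydroxy gives a 5.1-fold lower number from compound 1 to compound 4 (0.71 log units; beyond the scatter) in this assay and is the first single-change step available here. It shows that this aromatic carbon, para to a methyl group, responds to what it carries, and that the much smaller hydroxy outperforms the longer chain. No measured evidence explains this gain. The compounds shown leave open whether the result depends on the hydroxy itself or simply on removing the chain. Plain hydrogen, a methoxy group or an amine at this position would help separate those two readings.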